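Closing the Amine into a Ring: Compound 2 to Compound 3

The source may report more compounds than this note shows. Statements on the series, on what has been measured and on what is new or still open speak of the compounds shown alone.

Compound 1 `CCN(CC)CCCOc1cc2ncnc(Nc3nc4ccc(C(=O)Nc5c(C)cccc5C)cc4s3)c2cc1OC`: > 100000 nM, which is a limit of the assay.
Compound 2 `CCN(CC)CCCOc1cc2ncnc(Nc3nc4ccc(C(=O)Nc5c(C)cc(C)cc5C)cc4s3)c2cc1OC`: 7500 nM.

Within the data shown here, in a functional assay on HCT-116 cells (Homo sapiens) for cytotoxicity, read by WST assay, with a stated time of 72 h (a higher number here means a weaker inhibitor, a lower number a stronger inhibitor), compound 2 gives 7500 nM, the only number among the two results. Among the measured compounds shown here, the one measured step, an at least 13-fold lower number from compound 1 to compound 2 (1.12 log units; beyond the scatter), concerns a methyl in place of hydrogen on an aromatic carbon and does not touch the amine tail. Compound 3 `COc1cc2c(Nc3nc4ccc(C(=O)Nc5c(C)cc(C)cc5C)cc4s3)ncnc2cc1OCCCN1CCCC1` differs from compound 2 by pyrrolidin-1-yl in place of diethylamino on a saturated chain carbon, three bonds along the chain from an oxygen on an aromatic ring. For the measured compounds named here, no measured step bears on this change, so no shift beyond the scatter is expected in this assay. Compound 3 is therefore estimated at 7500 nM, between 2500 nM and 22000 nM, which is expected to mean no change at the digits printed from compound 2 to compound 3 (within the scatter).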

Compound 3, half-maximal inhibitory concentration: 5800 nM
Estimate against measurement, compound 3: 1.3-fold (0.11 log units) above, and the stated range covers the measured number.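

In this assay, closing the amine into a ring gives a 1.3-fold lower number from compound 2 to compound 3 (0.11 log units; within the scatter), so at this position, pyrrolidin-1-yl and diethylamino read alike. Among these compounds, this is the first reading on the amine tail, since the earlier step lay on an aromatic carbon. Nothing measured here bears on why the two amines read alike.

As far as these compounds go, whether piperidine, morpholine or a shorter chain such as 2-(pyrrolidin-1-yl)ethyl would shift the number stays open. So does whether this tail change would read the same on the core of compound 1.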